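Methylamino in Place of Methoxymethoxy: Expected Inhibitory Potency

The compounds below may be only part of what the source reports. "The series", "measured", "known", "first", "only" and "open" are said of these compounds alone.

Of the compounds shown here, three have been measured in an assay on isolated protein (strain Sprague-Dawley) for inhibition of Amine oxidase [flavin-containing] B (Rattus norvegicus), read by spectrophotometry, with a stated time of 5 min; a lower number here means a stronger inhibitor, a higher number a weaker inhibitor. Compound 1 `O=c1cc(O)c2ccc(OCc3cccc(Br)c3)cc2o1` gives 490 nM, compound 2 `COCOc1cc(=O)oc2cc(OCc3cccc(Cl)c3)ccc12` gives 100 nM, and compound 3 `NC(=O)COc1cc(=O)oc2cc(OCc3cccc(Br)c3)ccc12` gives 8.91 nM. Compound 2 thus stands second highest of the three, with compound 1 higher and compound 3 lower. Going by the values given here, the only measured step, a 55-fold lower number from compound 1 to compound 3 (1.74 log units; beyond the scatter), is a large drop at an oxygen on the aromatic ring. Compound 4 `CNc1cc(=O)oc2cc(OCc3cccc(Cl)c3)ccc12` differs from compound 2 by methylamino in place of methoxymethoxy on an aromatic carbon. Among the compounds with values here, no measured step covers this change, and the step from compound 1 to compound 3 concerns a different group, so only a modest shift of uncertain direction is expected. Compound 4 is therefore estimated at 150 nM, within 30 nM to 800 nM. The expected step of a 1.5-fold higher number from compound 2 to compound 4 (0.18 log units; within the scatter) stays near the scatter.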

Compound 4, half-maximal inhibitory concentration: 8.71 nM
For compound 4 the middle estimate is 17-fold (1.24 log units) above the measured one; measured number outside the range, below it.
By their numbers in this assay, from the lowest: compounds 4 and 3 (each within the scatter of the next); then compound 2; then compound 1.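

In this assay, methylamino in place of methoxymethoxy brings an 11-fold lower number from compound 2 to compound 4 (1.06 log units; beyond the scatter) on this aromatic carbon opposite the ring oxygen. The earlier compounds shown here all carried an oxygen on this carbon, and a 55-fold lower number from compound 1 to compound 3 (1.74 log units; beyond the scatter) showed only a change on that oxygen; this result shows that a group attached through nitrogen can also produce a large step here. Nothing available accounts for the size of this step. Going by these compounds, whether an unsubstituted amine, an ethylamino group or a dimethylamino group would give a similar number remains open. So does whether methylamino would have the same effect with bromine in place of chlorine.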